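Swapping the benzyl-ring substituent: chloro to nitro

This account rests on a few compounds, and the source may have more. Where it says the series, first, only, none or still open, it means among the compounds named here.

Compound 1 `Clc1ccccc1CSc1nnc(-c2ccncc2)n1-c1ccccc1` gives 13900 nM in a functional assay on HCT-116 cells (Homo sapiens) for inhibition, read by MTT assay, with a stated time of 48 h; a higher number here means a weaker inhibitor, a lower number a stronger inhibitor.
Compound 2 `Clc1cccc(CSc2nnc(-c3ccncc3)n2-c2ccccc2)c1` gives 9820 nM in this assay.
Compound 3 `Fc1ccc(CSc2nnc(-c3ccncc3)n2-c2ccccc2)c(F)c1` gives 11400 nM in this assay.

Compound 1 shows the highest of the three numbers, yet each of its neighbours sits within the scatter: a 1.4-fold lower number from compound 1 to compound 2 (0.15 log units; within the scatter) and a 1.2-fold lower number from compound 1 to compound 3 (0.09 log units; within the scatter). The unmeasured compound 4 `O=[N+]([O-])c1ccc(CSc2nnc(-c3ccncc3)n2-c2ccccc2)cc1` differs from compound 1 by 4-nitrophenyl in place of 2-chlorophenyl on a saturated chain carbon bound to a sulfur. Among the compounds with values here, no measured step introduces a 4-nitrophenyl, so the only guidance is that the two prior changes of the group on the saturated chain carbon bound to a sulfur left this assay essentially unchanged. Compound 4 is therefore expected to stay near compound 1, with a 1.2-fold lower number from compound 1 to compound 4 (0.06 log units; within the scatter) not exceeding the scatter. The estimate for compound 4 is 12000 nM, ranging from 5000 nM to 30000 nM.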

Compound 4, half-maximal inhibitory concentration: 23800 nM
Beside the measured number, compound 4's estimate is 2.0-fold (0.30 log units) below it; measured number inside the range.
By their numbers in this assay, from the lowest: compounds 2, 3, 1 and 4 (each within the scatter of the next, the first and the last beyond it).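

Within the data shown here, at this place, on a saturated chain carbon bound to a sulfur, 4-nitrophenyl gives the first steps beyond the scatter in this assay (a 2.1-fold higher number from compound 3 to compound 4 (0.32 log units; beyond the scatter); a 2.4-fold higher number from compound 2 to compound 4 (0.38 log units; beyond the scatter)), so this position is not wholly indifferent to the group it carries. Compound 1 goes against this pattern, since the change from 2-chlorophenyl remains unresolved (a 1.7-fold higher number from compound 1 to compound 4 (0.23 log units; within the scatter)). No measurement bears on why the number moves.

The compounds shown leave open whether the nitro group itself or its placement on the ring matters. Neither 4-chlorophenyl nor a ring-bound amine or carboxylic acid is among them to separate the two.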